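A few compounds are considered here, and "the series" means these few. Any claim that something is new, unique, unknown or untested is made for them only; others in the source may bear on it.

Compound 1 `Ic1ccc(OCCCCCn2ccnc2)cc1` carries a 1H-imidazol-1-yl group on a chain that ends in an oxygen on an aromatic ring. In an assay on microsomes from brain (strain Sprague-Dawley) for inhibition of heme oxygenase 2 (Rattus norvegicus), read by spectrophotometry, with a stated time of 60 min (a higher number here means a weaker inhibitor, a lower number a stronger inhibitor), compound 1 gives 900 nM. Compound 2 `Ic1ccc(OCCCCCCn2ccnc2)cc1` differs by (1H-imidazol-1-yl)methyl in place of 1H-imidazol-1-yl on a saturated chain carbon, five bonds along the chain from an oxygen on an aromatic ring. For compound 2 only a limit is reported in this assay, namely > 100000 nM. The step of an at least 110-fold higher number from compound 1 to compound 2 (2.04 log units; beyond the scatter) is therefore only a lower bound, because compound 2 sits at the limit of > 100000 nM in this assay, at which 1 of the 3 values shown sits.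

Compound 3 `Clc1ccc2sc(SCCCCn3ccnc3)nc2c1` has a different core; the difference between the two cores is not broken down here. In this assay compound 3 gives 900 nM. Compound 4 `Clc1ccc2sc(SCCCCCn3ccnc3)nc2c1` is not yet measured and differs from compound 3 by (1H-imidazol-1-yl)methyl in place of 1H-imidazol-1-yl on a saturated chain carbon, four bonds along the chain from a sulfur. This is the same kind of change as between compound 1 and compound 2, but the place differs: four bonds along the chain from a sulfur rather than five bonds from an oxygen on an aromatic ring. A weakening of about a 44-fold higher number from compound 3 to compound 4 (1.65 log units; beyond the scatter) is expected, resting on the step of an at least 110-fold higher number from compound 1 to compound 2 (2.04 log units; beyond the scatter). Compound 4 is estimated at 40000 nM in this assay, within 4000 nM to 200000 nM.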

Compound 4, half-maximal inhibitory concentration: 900 nM
The estimate for compound 4 lay 44-fold (1.65 log units) above the measured number; the whole stated range lies above it.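

In this assay the change gives no change at the digits printed from compound 3 to compound 4 (within the scatter), so the large loss seen on the core of compound 1 does not carry over to this core. Set side by side, the two results differ clearly: the same change on two cores in this assay, an at least 110-fold higher number (2.04 log units; beyond the scatter) from compound 1 to compound 2 and no change at the digits printed (within the scatter) from compound 3 to compound 4, at least 110-fold (2.04 log units) apart, beyond the scatter of two such steps. Among the compounds shown here, with only one pair on each core, this shows that the change cannot be assumed to act alike on both cores, but not why they differ or how any other core would respond.

The compounds shown leave open whether a longer chain on the core of compound 4 would eventually bring a loss like the one on the core of compound 1. They also leave open whether an amine in place of the 1H-imidazol-1-yl group would be tolerated on either core.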